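This account rests on a few compounds, and the source may have more. Where it says the series, first, only, none or still open, it means among the compounds named here.

Measured so far:
compound 1, `O=C(O)c1cc(-c2ncccn2)ccc1O`, 100 mg/kg
compound 2, `O=C(O)c1cc(-n2cccc2)ccc1O`, 50 mg/kg

Both numbers come from a functional assay on the whole organism for inhibition, with Rattus norvegicus as the target, read by paw edema; a lower number here means that less compound is needed, a higher number that more compound is needed for the effect. Compound 2 has the lower of the two numbers, but compound 1 stands only a little higher, and that gap lies within the scatter of repeated measurements, so the two are not told apart on these data. Compound 1 and compound 2 differ only in the ring carried on the shared core, and that exchange left the read-out essentially unchanged.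

The next compound in the series is compound 3, `O=C(O)c1cc(-c2nccs2)ccc1O`. It differs from compound 2 in one place: 1,3-thiazol-2-yl in place of 1H-pyrrol-1-yl on an aromatic carbon. For the measured compounds named here, no pair of measured compounds shows this exact exchange, so its effect cannot be read from a step already seen. Going by the values given here, the one comparison available, compound 1 against compound 2, shows that swapping the ring at this place changes the number by no more than the scatter, so the expectation for compound 3 is a step of similar size, with no clear direction. The expected step is a 1.2-fold higher number from compound 2 to compound 3 (0.08 log units; within the scatter). Compound 3 is estimated at 60 mg/kg, with a range from 25 mg/kg to 140 mg/kg.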

Compound 3, dose for half-maximal effect: > 250 mg/kg
Compound 3: only a limit was reported; the forecaster's own chance of this, stated with the estimate: 5%; at least 4.1-fold (0.61 log units) between middle value and limit.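

In this assay, the ring on this aromatic carbon, para to a hydroxy group, cannot be exchanged freely: 1,3-thiazol-2-yl in place of 1H-pyrrol-1-yl gives an at least 5.0-fold higher number from compound 2 to compound 3 (0.69 log units; beyond the scatter), a step beyond the scatter of a kind that the pair of compound 1 and compound 2 did not show. Compound 3 gives > 250 mg/kg, which is a limit of the assay and not a number, and the step read from it is therefore a floor with no measured size: the limit of > 250 mg/kg in this assay, at which 1 of the 3 values shown sits. The entering and leaving rings are both five-membered and aromatic with the same count of heavy atoms, so within this pair, ring size and heavy-atom count do not account for the difference in the read-out.

The compounds shown do not separate the contribution of the sulfur from that of the second hetero atom in the 1,3-thiazol-2-yl ring. They also leave open how a group of another kind at this place, such as an amine or a longer alkyl chain, would read in this assay.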